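The source may report more compounds than this note shows. Statements on the series, on what has been measured and on what is new or still open speak of the compounds shown alone.

Measured compounds: compound 1 `O[C@@H](c1ccccc1)[C@H]1CO[C@H](c2ccccc2)[C@@H](C/C=C/c2ccccc2)C1` gives 7040 nM in a functional assay on HL-60 cells (Homo sapiens) for cytotoxicity, read by WST assay, with a stated time of 48 h; a higher number here means a weaker inhibitor, a lower number a stronger inhibitor; compound 2 `CCCCCC/C=C/C[C@H]1C[C@@H]([C@@H](O)c2ccccc2)CO[C@@H]1c1ccccc1` gives 4990 nM. Compound 3 `O[C@@H](c1ccccc1)[C@H]1CO[C@H](c2ccccc2)[C@@H](C/C=C/c2cccnc2)C1` returns only a limit of this assay, > 100000 nM.

Compound 1 and compound 2 lie within the scatter of each other, with a 1.4-fold lower number from compound 1 to compound 2 (0.15 log units; within the scatter). Compound 3 stands apart through an at least 14-fold higher number from compound 1 to compound 3 (1.15 log units; beyond the scatter) and an at least 20-fold higher number from compound 2 to compound 3 (1.30 log units; beyond the scatter); of the values shown, (the limit of > 100000 nM in this assay, at which 1 of the 3 values shown sits).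

Compound 4 `O[C@@H](c1ccccc1)[C@H]1CO[C@H](c2ccccc2)[C@@H](C/C=C/c2ccccc2F)C1` differs from compound 1 by fluoro in place of hydrogen on an aromatic carbon. For the measured compounds named here, no measured step touches the ring this way: an at least 14-fold higher number from compound 1 to compound 3 (1.15 log units; beyond the scatter) exchanges the whole phenyl for pyridin-3-yl, and a 1.4-fold lower number from compound 1 to compound 2 (0.15 log units; within the scatter) exchanges it for hexyl and stays within the scatter. A step within the scatter is therefore expected in this assay, a 1.2-fold lower number from compound 1 to compound 4 (0.07 log units; within the scatter). Compound 4 is estimated at 6000 nM, with a range of 2500 nM to 15000 nM.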

Compound 4, half-maximal inhibitory concentration: 9530 nM
For compound 4 the middle estimate is 1.6-fold (0.20 log units) below the measured one, and the stated range covers the measured number.
By their numbers in this assay, from the lowest: compounds 2, 1 and 4 (each within the scatter of the next). At a limit, above all of these: compound 3.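

In this assay, fluoro on an aromatic carbon, ortho to a large group, leaves the phenyl series within the scatter: a 1.4-fold higher number from compound 1 to compound 4 (0.13 log units; within the scatter). The 2-fluorophenyl chain end likewise stays within the scatter of the hexyl chain end, a 1.9-fold higher number from compound 2 to compound 4 (0.28 log units; within the scatter), yet remains far from the pyridin-3-yl chain end, an at least 10-fold lower number from compound 3 to compound 4 (1.02 log units; beyond the scatter). Among the chain ends shown, only the pyridin-3-yl of compound 3 stands apart, and its value is a limit: the limit of > 100000 nM in this assay, at which 1 of the 4 values shown sits.

Going by these compounds, whether an amine or a methoxy group at this position would stay within the scatter as fluoro does remains open. Chlorine at this position also remains untested by these values.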